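A few compounds are considered here, and "the series" means these few. Any claim that something is new, unique, unknown or untested is made for them only; others in the source may bear on it.

Measured so far:
- compound 1, `N#Cc1c(N)sc(C(=O)Nc2ccc(Cl)cc2)c1-c1ccccc1`: 700 nM
- compound 2, `CCOC(=O)c1c(NC(=O)CC#N)sc(C(=O)Nc2ccc(Cl)cc2)c1-c1ccccc1`: 600 nM
- compound 3, `N#Cc1c(N)sc(C(=O)Nc2ccccc2)c1-c1ccccc1`: 8280 nM

All three were tested in a functional assay on A549 cells (Homo sapiens) for inhibition, read by MTT assay; a lower number here means a stronger inhibitor, a higher number a weaker inhibitor. Compound 1 gives 700 nM and compound 2 gives 600 nM in this assay; these two numbers lie within the usual scatter of each other, so no order between them can be read. Compound 3 gives 8280 nM, clearly the highest of the three.

Compound 4, `CCOC(=O)c1c(NC(=O)CC#N)sc(C(=O)Nc2ccccc2)c1-c1ccccc1`, has not yet been measured. It is related to compound 2 in the same way that compound 3 is related to compound 1. The difference between the core of compound 1 and the core of compound 2 is not broken down here.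

The change from compound 1 to compound 3 is hydrogen in place of chloro on an aromatic carbon and it produced a 12-fold higher number from compound 1 to compound 3 (1.07 log units; beyond the scatter). The change from compound 2 to compound 4 is hydrogen in place of chloro on an aromatic carbon. The two place descriptions agree word for word, so this is the same change made on a different core.

For the measured compounds named here, with only one earlier example of this change, the expectation for compound 4 rests entirely on that one example: because a 12-fold higher number from compound 1 to compound 3 (1.07 log units; beyond the scatter) was large, a step of similar size is expected from compound 2, and the step to compound 4 is estimated as a 12-fold higher number from compound 2 to compound 4 (1.07 log units; beyond the scatter). On that basis compound 4 is expected to give about 7000 nM in this assay, estimated to fall between 2500 nM and 20000 nM.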

Compound 4, half-maximal inhibitory concentration: 320 nM
Estimate against measurement, compound 4: 22-fold (1.34 log units) above; the measured number lies below the stated range.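

Replacing 4-chlorophenyl with phenyl on the second core gives a 1.9-fold lower number from compound 2 to compound 4 (0.27 log units; within the scatter) in this assay, so on this core the swap produces no change that can be told apart from ordinary variation between repeat measurements. This same swap, which gave a large step on the first core, does not give a matching step here, and the two steps clearly disagree: the same change on two cores in this assay, a 12-fold higher number (1.07 log units; beyond the scatter) from compound 1 to compound 3 and a 1.9-fold lower number (0.27 log units; within the scatter) from compound 2 to compound 4, 22-fold (1.35 log units) apart, beyond the scatter of two such steps. For the compounds shown here, this shows that the size of the step seen on one core cannot simply be carried over to the other, but with only two pairs it gives no general rule for other cores, and it does not show which part of the difference between the cores is responsible or why the two steps disagree.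

On these data alone, it remains open how a bromo, methyl or methoxy group in place of the chloro would read on each of the two cores. A core that carries a free amine together with an ethyl ester would also help, since it could show which of the differences between the two cores goes with the large step and which does not.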